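Cyclohexyl for Fluorophenyl: Expecting Steady Acid Dissociation

The source may report more compounds than this note shows. Statements on the series, on what has been measured and on what is new or still open speak of the compounds shown alone.

Compound 1, `COc1cccc(CNCCCNc2ccnc3cc(Oc4ccc(Cl)cc4)ccc23)c1O`, gives 9.28 in a physicochemical assay for acid dissociation.
Compound 2, `COc1ccc(Oc2ccc3c(NCCCNCc4cccc(OC)c4O)ccnc3c2)cc1`, gives 9.28 in this assay.
Compound 3, `COc1cccc(CNCCCNc2ccnc3cc(Cc4ccc(F)cc4)ccc23)c1O`, gives 9.47 in this assay.

Compound 3 holds the highest of the three numbers, yet both steps toward it, a number 0.19 log units higher from compound 1 to compound 3 (within the scatter) and a number 0.19 log units higher from compound 2 to compound 3 (within the scatter), sit within the scatter, as does no change at the digits printed from compound 1 to compound 2 (within the scatter). Compound 4, `COc1cccc(CNCCCNc2ccnc3cc(CC4CCCCC4)ccc23)c1O`, differs from compound 3 in one place: cyclohexyl in place of 4-fluorophenyl on a saturated chain carbon bound to an aromatic carbon. Going by the values given here, every measured step so far exchanged a group on an aromatic carbon of the shared core and left the acid dissociation constant flat, so a move of the same kind in compound 4 is expected to read as no change beyond the scatter, a number 0.02 log units lower from compound 3 to compound 4 (within the scatter). Compound 4 is therefore estimated at 9.45, between 9.15 and 9.75.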

Compound 4, acid dissociation constant: 9.47
Compound 4: middle estimate off by 0.02 log units, on the low side; the measured number falls inside the stated range.
By their numbers in this assay, from the lowest: compounds 1, 2, 3 and 4 (each within the scatter of the next).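

In this assay the change gives no change at the digits printed from compound 3 to compound 4 (within the scatter) on a saturated chain carbon bound to an aromatic carbon, even though a six-membered aromatic ring carrying fluorine gives way to a non-aromatic ring of carbon only. Cyclohexylmethyl also stays within the scatter of both phenoxy groups, with a number 0.19 log units higher from compound 2 to compound 4 (within the scatter) and a number 0.19 log units higher from compound 1 to compound 4 (within the scatter) when it replaces 4-methoxyphenoxy and 4-chlorophenoxy. No available evidence explains this flat reading.
From the compounds shown here alone, whether an amine or a carboxylic acid on the cyclohexyl ring would move the number beyond the scatter remains open, as does the outcome for a longer chain.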